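The source may report more compounds than this note shows. Statements on the series, on what has been measured and on what is new or still open speak of the compounds shown alone.

Measured so far in a functional assay on HL-60 cells (Homo sapiens) for cytotoxicity, read by MTT assay, with a stated time of 72 h; on this read-out higher numbers stand for weaker inhibition and lower numbers for stronger inhibition:
compound 1, `COc1ccc(/C=C/C(=O)OCC(=O)Nc2ccccc2)cc1OC`: 46400 nM
compound 2, `CCOc1ccc(COc2c(OC)cc(/C=C/C(=O)OCC(=O)Nc3ccccc3)cc2OC)cc1`: > 200000 nM

Within the data shown here, compound 1 supplies the only number in this assay, and its reading of 46400 nM is the single fixed point of the series. For compound 2 this assay returns > 200000 nM, which is a limit of the assay and not a number. Among the measured compounds shown here, that reading of compound 2 sits at the limit of > 200000 nM in this assay, at which 1 of the 2 values shown sits, so no step between the two measured compounds can be sized. Compound 3, `COc1ccc(/C=C/C(=O)OCC(=O)Nc2ccc(Cl)cc2)cc1OC`, is yet to be measured in this assay. Its difference from compound 1 is chloro in place of hydrogen on an aromatic carbon. For the measured compounds named here, with no measured step to lean on, the change is expected to move the half-maximal inhibitory concentration only a little, a step of a 1.3-fold lower number from compound 1 to compound 3 (0.12 log units; within the scatter) that stays inside the usual scatter. Compound 3 is therefore estimated at 35000 nM in this assay, with a range of 12000 nM to 110000 nM.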

Compound 3, half-maximal inhibitory concentration: 31900 nM
Compound 3: middle estimate off by 1.1-fold (0.04 log units), on the high side, and the stated range covers the measured number.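

In this assay the series now has its first sized step, on the phenyl of the anilino group, with chloro in place of hydrogen: a 1.5-fold lower number from compound 1 to compound 3 (0.16 log units; within the scatter). This position, para to a large group, therefore accepts a single chlorine atom, and compound 1 and compound 3 cannot be told apart on this read-out. Nothing measured here bears on why the reading responds in this way.

Still open, as far as these compounds go, is whether this result holds for other groups at this position, such as methoxy, nitrile, an amine or a carboxylic acid, and for chloro elsewhere on the ring. Compound 2 reads > 200000 nM, a limit of the assay and not a number, so steps to it cannot be read.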